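Adding a Methyl on the Ring Nitrogen Substituent

A few compounds are considered here, and "the series" means these few. Any claim that something is new, unique, unknown or untested is made for them only; others in the source may bear on it.

Compound 1 `CN1CCN(c2ccc3c(c2)oc(=O)n3C(=O)NCCCCc2ccccc2)CC1=O`: in a physicochemical assay for solubility, read by HPLC, in phosphate buffer, measured as kinetic solubility, with a stated time of 1 h, at pH 7.4, tested at 250 uM (on this read-out higher numbers stand for higher solubility and lower numbers for lower solubility), compound 1 gives < 1000 nM, which is a limit of the assay rather than a number.
Compound 2 `CN1CCC(c2ccc3c(c2)oc(=O)n3C(=O)NCCCCc2ccccc2)CC1=O`: compound 2 gives 20000 nM.
Compound 3 `CCN1CCC(c2ccc3c(c2)oc(=O)n3C(=O)NCCCCc2ccccc2)CC1`: compound 3 gives 198000 nM.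

Among the numbers, compound 3 stands highest, and compound 2 is its nearest neighbour, with a 9.9-fold higher number from compound 2 to compound 3 (1.00 log units; beyond the scatter). Compound 4 `CC(C)N1CCC(c2ccc3c(c2)oc(=O)n3C(=O)NCCCCc2ccccc2)CC1` differs from compound 3 by methyl in place of hydrogen on a saturated chain carbon bound to an amine nitrogen in a ring and a saturated chain carbon, so the ethyl becomes an isopropyl. Every measured step, by contrast, exchanged a whole group on the aromatic carbon: an at least 20-fold higher number from compound 1 to compound 2 (1.30 log units; beyond the scatter), an at least 190-fold higher number from compound 1 to compound 3 (2.29 log units; beyond the scatter) and a 9.9-fold higher number from compound 2 to compound 3 (1.00 log units; beyond the scatter). None of them bears directly on a change this small at this place. The expectation is therefore no step beyond the scatter, a 1.2-fold lower number from compound 3 to compound 4 (0.07 log units; within the scatter). Compound 4 is estimated at 170000 nM, with a range from 80000 nM to 250000 nM.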

Compound 4, solubility: 50000 nM
Estimate against measurement, compound 4: 3.4-fold (0.53 log units) above; the whole stated range lies above it.
By their numbers in this assay, from the lowest: compound 2; then compound 4; then compound 3. At a limit, below all of these: compound 1.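

In this assay, one added methyl on a saturated chain carbon bound to an amine nitrogen in a ring is enough to move the number, with a 4.0-fold lower number from compound 3 to compound 4 (0.60 log units; beyond the scatter), so even this small change at this place counts. The whole-group exchanges still favour the 1-isopropylpiperidin-4-yl group, with a 2.5-fold higher number from compound 2 to compound 4 (0.40 log units; beyond the scatter) and an at least 50-fold higher number from compound 1 to compound 4 (1.69 log units; beyond the scatter). Compound 1 stands at a limit, not a number: the limit of < 1000 nM in this assay, at which 1 of the 4 values shown sits.

As far as these compounds go, how a cyclopropyl or a tert-butyl group would read in place of the isopropyl stays open. So does the effect of a hydroxyl on that chain carbon.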